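The compounds below may be only part of what the source reports. "The series", "measured", "known", "first", "only" and "open" are said of these compounds alone.

Within the data shown here, in a functional assay on A549 cells (Homo sapiens) for inhibition, read by MTT assay, with a stated time of 72 h (on this read-out higher numbers stand for weaker inhibition and lower numbers for stronger inhibition), compound 1 `COc1cc(OC)c(C(=O)/C=C/c2ccc(O)cc2)c(OC)c1` gives 49400 nM and compound 2 `COc1cc(OC)c(C(=O)/C=C/c2ccc([N+](=O)[O-])cc2)c(OC)c1` gives 7100 nM as the lower of the two numbers so far, which means the stronger inhibition of the pair. Compound 3 `COc1cc(OC)c(C(=O)/C=C/c2ccc(C(F)(F)F)cc2)c(OC)c1` keeps the core of compound 2 and carries trifluoromethyl in place of nitro on an aromatic carbon, a swap counted as trifluoromethyl in place of nitro on an aromatic carbon and not yet measured. Among the measured compounds shown here, only one measured step bears on it: nitro in place of hydroxy on an aromatic carbon gave a 7.0-fold lower number from compound 1 to compound 2 (0.84 log units; beyond the scatter) as a modest change. That step involves nitro but shows nothing directly about trifluoromethyl, so no step beyond the scatter is expected in this assay for the new swap, perhaps with a slight drift toward a higher number. The estimated step is a 1.4-fold higher number from compound 2 to compound 3 (0.15 log units; within the scatter) and stays small. Compound 3 is expected at 10000 nM with an estimated range from 4000 nM to 25000 nM in repeat measurements.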

Compound 3, half-maximal inhibitory concentration: 14200 nM
The estimate for compound 3 lay 1.4-fold (0.15 log units) below the measured number; measured number inside the range.
By their numbers in this assay, from the lowest: compounds 2 and 3 (each within the scatter of the next); then compound 1.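

In this assay, the two groups at this place, on an aromatic carbon para to a large group, cannot be told apart: the result is a 2.0-fold higher number from compound 2 to compound 3 (0.30 log units; within the scatter), so the swap removes the hydrogen-bond acceptors counted on nitro without a step beyond the scatter. Hydroxy now stands apart from a second group, with a 3.5-fold lower number from compound 1 to compound 3 (0.54 log units; beyond the scatter), which means that the earlier gain over compound 1 is not confined to nitro. No measurement here gives a reason for either result.

From the compounds shown here alone, whether a nitrile, an amine or a carboxylic acid at this place would sit with compound 2 and compound 3 or nearer compound 1 remains open. Also open, going by these compounds, is whether a methoxy group would keep the number of compound 1, which would tell whether the free hydroxy itself matters.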